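Removing One Fluorine: What Happens to Hemolysis?

A few compounds are considered here, and "the series" means these few. Any claim that something is new, unique, unknown or untested is made for them only; others in the source may bear on it.

The measured compounds so far:
- compound 1 `N=C(N)c1ccc(-c2ccc(-c3ccc(F)cc3)o2)o1` gives 66.3%
- compound 2 `COc1cc(-c2ccc(-c3ccc(C(=N)N)s3)s2)cc(OC)c1OC` gives 38.7%

Both were tested in an ADME assay on cells (Erythrocyte, Homo sapiens) for activation, read by hemolysis, with a stated time of 30 min, tested at 5 mM; a lower number here means a weaker effect, a higher number a stronger effect of the compound at the concentration tested. Of the two numbers, compound 1 stands highest; the nearest is compound 2, whose value is lower by an amount beyond the usual scatter. Within the data shown here, the two measured compounds differ in more than one place, so no single step between them has been worked out, and their values say only what each shows on its own.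

Compound 3 `N=C(N)c1ccc(-c2ccc(-c3ccccc3)o2)o1` has not yet been measured in this assay. It differs from compound 1 in one place: hydrogen in place of fluoro on an aromatic carbon. A change of one atom of this kind is small compared with the differences between the two measured compounds. The expected step of a number 8.3 percentage points lower from compound 1 to compound 3 (within the scatter) is therefore downward but modest, and it is likely to stay within the scatter. Because compound 1 gives 66.3%, its close relative is expected to land somewhat below that. Compound 3 is expected to come out near 58%, with a likely range from 42% to 74%.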

Compound 3, a percentage reported as activity, at one concentration (the size of the read-out at that concentration, not a potency): 30.1%
Estimate against measurement, compound 3: 27.9 percentage points above, and the stated range ends above it.
By their numbers in this assay, from the lowest: compounds 3 and 2 (each within the scatter of the next); then compound 1.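

Exchanging the fluoro group for hydrogen gives a number 36.2 percentage points lower from compound 1 to compound 3 (beyond the scatter) in this assay, so this one position on the six-membered aromatic ring, para to a large group, has a clear bearing on the read-out. Compounds 1 and 2 differ in more than one place and could not tie a change in the number to any single site, whereas this pair does so, and it shows that replacing one atom can produce a large step. The data offer no measurement that accounts for the size of this step, so its cause remains unknown.

Going by these compounds, what stays open is whether this carbon responds to fluorine in particular or to the presence of any group other than hydrogen, a question that a chloro group or an amine in the same place could help answer. On these data alone, it is also open whether the same exchange would produce a step of similar size on a different core, since this single pair speaks only for the core of compound 1.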